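This account rests on a few compounds, and the source may have more. Where it says the series, first, only, none or still open, it means among the compounds named here.

Measured so far:
- compound 1, `COc1cc(-c2nnc(SCC(=O)c3ccccc3)n2N)cc(OC)c1OC`: in a functional assay on PC-3 cells (Homo sapiens) for antiproliferative activity, read by MTT assay, with a stated time of 48 h (on this read-out higher numbers stand for weaker inhibition and lower numbers for stronger inhibition), compound 1 gives > 100000 nM, a limit of the assay.
- compound 2, `COc1cc(-c2nnc(SCC(=O)c3ccc(Br)cc3)n2N)cc(OC)c1OC`: in this assay compound 2 gives > 100000 nM, also a limit.
- compound 3, `COc1cc(-c2nnc(SCC(=O)c3ccc(C)cc3)n2N)cc(OC)c1OC`: in this assay compound 3 gives 31300 nM.

For the measured compounds named here, compound 3 thus holds the only number among the three; the other two sit at the limit of > 100000 nM in this assay, at which 2 of the 3 values shown sit. The step of an at least 3.1-fold lower number from compound 1 to compound 3 (0.50 log units; beyond the scatter) and the step of an at least 3.1-fold lower number from compound 2 to compound 3 (0.50 log units; beyond the scatter) both point the same way, while a step that the two limits leave unreadable from compound 1 to compound 2 cannot be sized.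

Compound 4, `COc1cc(-c2nnc(SCC(=O)c3ccc(C(F)(F)F)cc3)n2N)cc(OC)c1OC`, differs from compound 3 by trifluoromethyl in place of methyl on an aromatic carbon. Going by the values given here, no measured step covers this exchange; the two usable steps only show that methyl beats hydrogen and bromo here, so no clear direction is expected in this assay for compound 4, with a real chance of a limit. Compound 4 is estimated at 45000 nM (range 15000 nM to 150000 nM), meaning an expected step of a 1.4-fold higher number from compound 3 to compound 4 (0.16 log units; within the scatter).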

Compound 4, half-maximal inhibitory concentration: > 100000 nM
Compound 4 gave a limit, no number (the forecaster's own chance of this, stated with the estimate: 35%); at least 2.2-fold (0.34 log units) between middle value and limit.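

In this assay, the change from 4-methylphenyl to 4-(trifluoromethyl)phenyl gives an at least 3.1-fold higher number from compound 3 to compound 4 (0.50 log units; beyond the scatter). At this position, para to a large group, methyl is thus the only one of the four substituents shown to give a number, and trifluoromethyl does not share that outcome despite also being a one-carbon group. The steps among compound 1, compound 2 and compound 4 cannot be read, so these three cannot be ordered: the limit of > 100000 nM in this assay, at which 3 of the 4 values shown sit.

Open, on these data alone, is how an ethyl group or an amine at this position would compare with methyl. Also open, as far as these compounds go, is whether any substituent here would give a much lower number than compound 3 does.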